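Shifting the Carboxy Group Along the Same Ring

The source may report more compounds than this note shows. Statements on the series, on what has been measured and on what is new or still open speak of the compounds shown alone.

compound 1 `Cc1c(OCCCCOc2cccc(C(=O)O)c2)ccc(C(=O)CC(C)C)c1O`: 51%
compound 2 `Cc1cc(C(=O)O)ccc1OCCCCOc1ccc(C(=O)CC(C)C)c(O)c1C`: 41%

In an ADME assay (liver) for metabolic stability, with Liver microsome (Rattus norvegicus) as the target, read by LC-MS, using microsomes and NADPH, with stated times of 5 min and 60 min, tested at 4 uM (a lower number here means that less of the compound is left, a higher number that more of the compound is left), compound 2 gives 41% and stands lowest of the two numbers, with compound 1 nearest at 51%; the step of a number 10 percentage points lower from compound 1 to compound 2 (within the scatter) lies within the scatter. Compound 3 `Cc1ccc(C(=O)O)cc1OCCCCOc1ccc(C(=O)CC(C)C)c(O)c1C` differs from compound 2 by 5-carboxy-2-methylphenyl in place of 4-carboxy-2-methylphenyl on an oxygen on a saturated carbon. For the measured compounds named here, no measured step moves the carboxy group along the same ring, and the only step on record, a number 10 percentage points lower from compound 1 to compound 2 (within the scatter), concerned a different exchange and stayed within the scatter. No step beyond the scatter is therefore expected in this assay. Compound 3 is expected to give about 43%, between 28% and 58%. The step this estimate means is expected to be a number 2 percentage points higher from compound 2 to compound 3 (within the scatter).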

Compound 3, percent of the compound remaining: 21%
Estimate against measurement, compound 3: 22 percentage points above; the measured number lies below the stated range.
By their numbers in this assay, from the lowest: compound 3; then compounds 2 and 1 (each within the scatter of the next).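

In this assay, 5-carboxy-2-methylphenyl in place of 4-carboxy-2-methylphenyl gives a number 20 percentage points lower from compound 2 to compound 3 (beyond the scatter) even though the two compounds have the same atoms, so how these atoms are joined in this group can matter. Methyl in place of hydrogen on an aromatic carbon, the change that links the other pair, gives a number 30 percentage points lower from compound 1 to compound 3 (beyond the scatter) and adds a second step beyond the scatter. No measurement here explains either step. From the compounds shown here alone, whether an amide in place of the carboxy group, or a longer chain on the oxygen, would preserve these differences stays open.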